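The compounds below may be only part of what the source reports. "The series", "measured", "known", "first", "only" and "open" are said of these compounds alone.

Compound 1 `CC(C)(C)c1ccc(C(=O)Nc2cccc(NC(=O)COc3ccc4c(=O)ccoc4c3)c2)cc1` gives 34 nM.
Compound 2 `O=C(COc1ccc2c(=O)ccoc2c1)Nc1cccc(NC(=O)c2ccc(F)cc2)c1` gives 54 nM.
Compound 3 `CCOc1ccc(C(=O)Nc2cccc(NC(=O)COc3ccc4c(=O)ccoc4c3)c2)cc1` gives 9 nM.

In an assay on isolated protein for inhibition of Rho-associated protein kinase 2 (Homo sapiens), read by scintillation counting, radiometric assay and 33P incorporation, with a stated time of 40 min, in the presence of a further agent that is not named here (on this read-out lower numbers stand for stronger inhibition and higher numbers for weaker inhibition), compound 3 stands with the lowest of the three numbers, reached through a 3.8-fold lower number from compound 1 to compound 3 (0.58 log units; beyond the scatter) and a 6.0-fold lower number from compound 2 to compound 3 (0.78 log units; beyond the scatter), while a 1.6-fold higher number from compound 1 to compound 2 (0.20 log units; within the scatter) is within the scatter. Compound 4 `Cc1cc(C(=O)Nc2cccc(NC(=O)COc3ccc4c(=O)ccoc4c3)c2)no1` differs from compound 3 as follows: 5-methyl-1,2-oxazol-3-yl in place of 4-ethoxyphenyl on a carbonyl carbon. The measured steps each swap one small group on an aromatic carbon of the same six-membered ring; none exchanges that whole ring for a five-membered heteroaromatic, so they bear on the new step only loosely. The ethoxy group that gave the best number is lost, so a moderate rise is expected, about a 4.4-fold higher number from compound 3 to compound 4 (0.65 log units; beyond the scatter). Compound 4 is estimated at 40 nM, within 12 nM to 150 nM.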

Compound 4, half-maximal inhibitory concentration: 5 nM
Compound 4: the middle estimate sits 8.0-fold (0.90 log units) above what was measured, outside the stated range (below it).
By their numbers in this assay, from the lowest: compounds 4 and 3 (each within the scatter of the next); then compounds 1 and 2 (each within the scatter of the next).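

In this assay, the whole 4-ethoxyphenyl group on the carbonyl carbon can be replaced by 5-methyl-1,2-oxazol-3-yl, and the two numbers stay close: a 1.8-fold lower number from compound 3 to compound 4 (0.26 log units; within the scatter). This position therefore accepts a five-membered aromatic ring with 2 hetero atoms, and a low number does not depend on the ethoxy group, as the new group also clearly beats the other two phenyl groups, with an 11-fold lower number from compound 2 to compound 4 (1.03 log units; beyond the scatter) and a 6.8-fold lower number from compound 1 to compound 4 (0.83 log units; beyond the scatter). Nothing available explains this result. Still open, as far as these compounds go, is whether the methyl on the new ring matters, and how a ring carrying an amine or a carboxylic acid would behave here.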